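The source may report more compounds than this note shows. Statements on the series, on what has been measured and on what is new or still open speak of the compounds shown alone.

Measured in a functional assay for inhibition, with Sus scrofa as the target; on this read-out lower numbers stand for stronger inhibition and higher numbers for weaker inhibition:
- Compound 1 `CC1(C)Oc2ccc(C#N)cc2[C@@H](Nn2ccccc2=O)[C@]1(C)O`: > 100000 nM
- Compound 2 `CC1(C)Oc2ccc(C#N)cc2[C@@H](OC2=CC(=O)CC2)[C@]1(C)O`: 20 nM

Compound 1 gives only a limit, not a number: the limit of > 100000 nM in this assay, at which 1 of the 2 values shown sits. Compound 3 `Cn1nc(N[C@@H]2c3cc(C#N)ccc3OC(C)(C)[C@@]2(C)O)ccc1=O` keeps the core of compound 1 and exchanges the ring group on the amine nitrogen: a group of 8 heavy atoms (5 carbon, 2 nitrogen, 1 oxygen; one six-membered aromatic ring with 2 hetero atoms) in place of a group of 7 heavy atoms (5 carbon, 1 nitrogen, 1 oxygen; one six-membered aromatic ring with 1 hetero atom), on an amine nitrogen. Among the measured compounds shown here, only one measured step bears on this change. Replacing the group at this same part of compound 1 gave an at least 5000-fold lower number from compound 1 to compound 2 (3.69 log units; beyond the scatter). Compound 2 carries a different group from compound 3, so that step shows how far this assay can move with a change here, but does not fix the outcome for compound 3. A large step towards a lower number, meaning stronger inhibition, is still expected, though probably a smaller one than that measured step. The expected change is an at least 200-fold lower number from compound 1 to compound 3 (2.30 log units; beyond the scatter). For compound 3 the estimated value is 500 nM. The expected range for compound 3 runs from 30 nM to 20000 nM.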

Compound 3, half-maximal inhibitory concentration: 20 nM
The estimate for compound 3 lay 25-fold (1.40 log units) above the measured number; measured number below the stated range.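

In this assay, the ring group on the amine nitrogen proves decisive, with the change from compound 1 to compound 3 giving an at least 5000-fold lower number from compound 1 to compound 3 (3.69 log units; beyond the scatter). Compound 1 stands at a limit of the assay, not at a number: the limit of > 100000 nM in this assay, at which 1 of the 3 values shown sits. Compound 2 gives 20 nM and compound 3 gives 20 nM, so strong inhibition at this part of the molecule does not depend on the group carried by compound 2, and the core with a group on an amine nitrogen can reach the same printed value.

What remains open is which feature of the entering ring accounts for the step, as a single pair cannot separate its parts. It is also unknown how a plain phenyl ring, a pyrimidine ring or a carboxylic acid on the same amine nitrogen would behave.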